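The compounds below may be only part of what the source reports. "The series", "measured", "known", "first", "only" and "open" are said of these compounds alone.

Of the compounds shown here, two have so far been measured in a functional assay for agonist activity at Alpha-1A adrenergic receptor (Homo sapiens); on this read-out lower numbers stand for an effect already at smaller amounts and higher numbers for an effect only at larger amounts of compound. Compound 2, with the structure `CSc1ccc(F)cc1NCC1=NCCN1`, gives 2.29 nM in this assay. Compound 1, with the structure `COc1ccc(S(C)(=O)=O)c(NCC2=NCCN2)c1`, gives 14.1 nM in this assay. Compound 2 thus stands at the lower of the two numbers, and the gap to compound 1 lies beyond the usual scatter of repeated measurements, so compound 2 takes effect at the smaller amount.

Compound 3, with the structure `COc1ccc(SC)c(NCC2=NCCN2)c1`, has not yet been measured. It differs from compound 2 in a single place: methoxy in place of fluoro on an aromatic carbon. The fluoro leaves and a methoxy enters on the same aromatic carbon of the six-membered carbon ring, para to the methylsulfanyl group and meta to the group of 7 heavy atoms. Going by the values given here, the methoxy is also found in compound 1, but compound 1 differs from compound 3 in a second place as well, so no single step with a known size points the way.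

The expectation for this exchange is a small rise in the number, of a size that may stay within the scatter, giving a step of a 1.7-fold higher number from compound 2 to compound 3 (0.24 log units; within the scatter) from compound 2 to compound 3. Compound 3 is therefore estimated to give 4 nM in this assay, with a range from 1.5 nM to 12 nM.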

Compound 3, half-maximal effective concentration: 1.59 nM
Estimate against measurement, compound 3: 2.5-fold (0.40 log units) above; the range from low to high includes it.
By their numbers in this assay, from the lowest: compounds 3 and 2 (each within the scatter of the next); then compound 1.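

In this assay, methoxy in place of fluoro on the aromatic carbon para to the methylsulfanyl group gives a 1.4-fold lower number from compound 2 to compound 3 (0.16 log units; within the scatter) and so this place carries either group, one of a single fluorine atom and the other of two heavy atoms with a hydrogen-bond acceptor, with no difference that can be told from the scatter. Going by these compounds alone, compound 3 also provides the first comparison with compound 1 in which only one place differs: methylsulfanyl in place of methylsulfonyl gives an 8.9-fold lower number from compound 1 to compound 3 (0.95 log units; beyond the scatter) and this shows that a clear difference can arise at the sulfur-bearing group with the methoxy held constant. Nothing available explains either step.

On these data alone, how far this openness at the methoxy place extends remains unknown, since a longer chain such as propoxy, an amine or a carboxylic acid there could give a very different number. At the sulfur-bearing group, the intermediate methylsulfinyl and the longer ethylsulfanyl would show whether the difference between methylsulfanyl and methylsulfonyl belongs to these two groups alone or forms part of a wider trend.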